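Replacing 1-benzofuran-4-yl in compound 2

This account rests on a few compounds, and the source may have more. Where it says the series, first, only, none or still open, it means among the compounds named here.

Measured in a physicochemical assay for solubility; on this read-out lower numbers stand for lower solubility and higher numbers for higher solubility:
Compound 1 `CNC(=O)c1cc(C(=O)NC2CC2)cn(Cc2cccc3[nH]ncc23)c1=O`: 10 ug/mL
Compound 2 `CNC(=O)c1cc(C(=O)NC2CC2)cn(Cc2cccc3occc23)c1=O`: >= 110 ug/mL, a limit of the assay

Compound 2 stands on (the limit of >= 110 ug/mL in this assay, at which 1 of the 2 values shown sits). Compound 3 `CNC(=O)c1cc(C(=O)NC2CC2)cn(Cc2cccc3cc[nH]c23)c1=O` carries 1H-indol-7-yl in place of 1-benzofuran-4-yl on a saturated chain carbon bound to an aromatic nitrogen. Among the measured compounds shown here, the one measured step bearing on this is large: an at least 11-fold higher number from compound 1 to compound 2 (1.04 log units; beyond the scatter). It replaced 1H-indazol-4-yl with 1-benzofuran-4-yl, and the change now brings back a hydrogen-bond donor, so part of that step is expected to reverse. The expected change in this assay is an at least 2.2-fold lower number from compound 2 to compound 3 (0.34 log units; beyond the scatter), towards a lower number. Compound 3 is estimated at 50 ug/mL, with an expected range of 15 ug/mL to 150 ug/mL.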

Compound 3, solubility: >= 144 ug/mL
Compound 3 was reported as a limit; the forecaster's own chance of this, stated with the estimate: 25%; middle value at least 2.8-fold (0.45 log units) from the limit.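

In this assay, compound 3 sits at a limit of the assay: the limit of >= 144 ug/mL in this assay, at which 1 of the 3 values shown sits. Placing 1H-indol-7-yl instead of 1H-indazol-4-yl on the saturated chain carbon bound to an aromatic nitrogen gives an at least 14-fold higher number from compound 1 to compound 3 (1.15 log units; beyond the scatter). The entering group carries a hydrogen-bond donor and the read-out still reaches a limit, so the large step seen earlier is not undone here. Going by these compounds, the step between compound 2 and compound 3 cannot be read, and the order of these two stays unknown. On these data alone, how an amine or a carboxylic acid at this place would read in this assay also stays open.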